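From 3-carboxyazetidin-1-yl to 3-hydroxypyrrolidin-1-yl

A few compounds are considered here, and "the series" means these few. Any claim that something is new, unique, unknown or untested is made for them only; others in the source may bear on it.

In a functional assay on MC-38 cells (Mus musculus) for antiproliferative activity, read by CCK-8 assay, with a stated time of 48 h (on this read-out higher numbers stand for weaker inhibition and lower numbers for stronger inhibition), compound 3 (`COc1ccc(/C=C\c2cc(OC)c(OC)c(OC)c2)cc1OCc1ccc(CN2CC(C(=O)O)C2)cc1`) gives > 10000 nM, which is a limit and not a number. Compound 1 (`COc1ccc(/C=C\c2cc(OC)c(OC)c(OC)c2)cc1OCc1ccc(CNC(C)(C)C(=O)O)cc1`) gives > 10000 nM, which is also a limit. Compound 3 therefore stands at the limit of > 10000 nM in this assay, at which 2 of the 3 values shown sit. Compound 2 (`COc1ccc(/C=C\c2cc(OC)c(OC)c(OC)c2)cc1OCc1ccc(CN2CCCCC2C(=O)O)cc1`) alone has a readable number, 5400 nM.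

Compound 4 (`COc1ccc(/C=C\c2cc(OC)c(OC)c(OC)c2)cc1OCc1ccc(CN2CC[C@@H](O)C2)cc1`) carries a new group on a saturated chain carbon bound to an aromatic carbon: 3-hydroxypyrrolidin-1-yl in place of 3-carboxyazetidin-1-yl on a saturated chain carbon bound to an aromatic carbon.

Going by the values given here, three measured steps bear on this change, though each only exchanges one carboxy-bearing group for another: an at least 1.8-fold lower number from compound 1 to compound 2 (0.26 log units; that floor lies within the scatter), a step that the two limits leave unreadable from compound 1 to compound 3 and an at least 1.8-fold higher number from compound 2 to compound 3 (0.26 log units; that floor lies within the scatter). None removes the carboxy group, so they guide the size of the new step only weakly. A move towards stronger inhibition in this assay is expected, with compound 2 at 5400 nM as the only readable reference, but its size is uncertain. The expected step is an at least 6.6-fold lower number from compound 3 to compound 4 (0.82 log units; beyond the scatter). Compound 4 is estimated at 1500 nM, with an expected range of 150 nM to 10000 nM.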

Compound 4, half-maximal inhibitory concentration: 6900 nM
Compound 4: the middle estimate sits 4.6-fold (0.66 log units) below what was measured, within the range that was stated.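

In this assay the hydroxy group of 3-hydroxypyrrolidin-1-yl takes the place of a carboxy group, and against the only readable carboxy-bearing reference this exchange stays within the scatter: a 1.3-fold higher number from compound 2 to compound 4 (0.11 log units; within the scatter). Against the two limits only floors can be read, and both lie within the scatter: an at least 1.4-fold lower number from compound 3 to compound 4 (0.16 log units; that floor lies within the scatter) and an at least 1.4-fold lower number from compound 1 to compound 4 (0.16 log units; that floor lies within the scatter). A carboxy group is thus not needed for a readable value at this place, while two carboxy-bearing compounds remain at a limit: the limit of > 10000 nM in this assay, at which 2 of the 4 values shown sit.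

The compounds shown leave open how much of the result belongs to the ring and how much to the hydroxy group. A 3-carboxypyrrolidin-1-yl group or an unsubstituted pyrrolidin-1-yl group at the same place would separate the two.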